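This account rests on a few compounds, and the source may have more. Where it says the series, first, only, none or still open, it means among the compounds named here.

The shared core carries a triazole whose aromatic nitrogen bears a changeable aryl group, and three such compounds have been measured. In a functional assay on HCT-116 cells (Homo sapiens) for cytotoxicity, read by MTT assay, with a stated time of 24 h (on this read-out lower numbers stand for stronger inhibition and higher numbers for weaker inhibition), compound 1 `COc1ccc(/C=C\C(=O)O)c(OCc2cn(-c3ccc(NC(=O)c4ccccc4)cc3)nn2)c1CC=C(C)C` gives 16400 nM. Compound 2 `COc1cccc(-n2cc(COc3c(/C=C\C(=O)O)ccc(OC)c3CC=C(C)C)nn2)c1` gives 21600 nM in this assay, and compound 3 `COc1ccc(/C=C\C(=O)O)c(OCc2cn(-c3ccccc3I)nn2)c1CC=C(C)C` gives 23100 nM. The number for compound 2 sits between those of compound 1 and compound 3, and both of those neighbours lie within the scatter of it. Among the measured compounds shown here, the one single-point step among them, a 1.1-fold higher number from compound 2 to compound 3 (0.03 log units; within the scatter), shows that swapping the aryl group on the aromatic nitrogen left the read-out essentially unchanged. Compound 4 `COc1ccc(/C=C\C(=O)O)c(OCc2cn(-c3nc4ccccc4s3)nn2)c1CC=C(C)C` differs from compound 2 by 1,3-benzothiazol-2-yl in place of 3-methoxyphenyl on an aromatic nitrogen. For the measured compounds named here, only the step from compound 2 to compound 3 bears directly on this change, and it was within the scatter, so no step beyond the scatter is expected in this assay for compound 4 in either direction. Compound 4 is therefore estimated at 20000 nM, with a range from 8000 nM to 50000 nM, which is expected to amount to a 1.1-fold lower number from compound 2 to compound 4 (0.03 log units; within the scatter).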

Compound 4, half-maximal inhibitory concentration: 16400 nM
Estimate against measurement, compound 4: 1.2-fold (0.09 log units) above; measured number inside the range.
By their numbers in this assay, from the lowest: compounds 1, 4, 2 and 3 (each within the scatter of the next).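

With compound 4, the group on the aromatic nitrogen is no longer a substituted phenyl but 1,3-benzothiazol-2-yl, which adds a five-membered aromatic ring with 2 hetero atoms to the six-membered ring of carbon only. In this assay, this exchange gives a 1.3-fold lower number from compound 2 to compound 4 (0.12 log units; within the scatter) and a 1.4-fold lower number from compound 3 to compound 4 (0.15 log units; within the scatter), so for these compounds the read-out does not separate this group from either 3-methoxyphenyl or 2-iodophenyl. Nothing given here explains this result.

On these data alone, it remains open whether a different kind of group on this nitrogen, such as a plain alkyl chain, a cyclohexyl ring or a phenyl bearing an amine, would give a step beyond the scatter. The compounds shown also leave open whether the same exchanges would stay within the scatter in any read-out other than this assay.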